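Para substituent on the aryl ring: tert-butyl to methoxy

This account rests on a few compounds, and the source may have more. Where it says the series, first, only, none or still open, it means among the compounds named here.

Compounds measured so far:
compound 1 `NS(=O)(=O)NCC1CCN(c2cc(-c3ccccc3)ncn2)CC1`: > 100000 nM
compound 2 `CCCCc1ccc(-c2cc(N3CCC(CNS(N)(=O)=O)CC3)ncn2)cc1`: 15200 nM
compound 3 `CC(C)(C)c1ccc(-c2cc(N3CCC(CNS(N)(=O)=O)CC3)ncn2)cc1`: 8900 nM

The three compounds share one core and differ only at one aromatic carbon. In a functional assay on HT-29 cells (Homo sapiens) for antiproliferative activity, read by sulforhodamine B assay, with a stated time of 48 h (a lower number here means a stronger inhibitor of growth, a higher number a weaker inhibitor of growth), compound 1 reaches only a limit of the assay, > 100000 nM. Compound 2, carrying butyl, gives 15200 nM; compound 3, carrying tert-butyl, gives 8900 nM and holds the lowest of the two numbers, though the two sit within the scatter of each other (a 1.7-fold lower number from compound 2 to compound 3 (0.23 log units; within the scatter)). The steps from hydrogen are an at least 6.5-fold lower number from compound 1 to compound 2 (0.81 log units; beyond the scatter) and an at least 11-fold lower number from compound 1 to compound 3 (1.05 log units; beyond the scatter).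

Compound 4 `COc1ccc(-c2cc(N3CCC(CNS(N)(=O)=O)CC3)ncn2)cc1` is not yet measured. The change from compound 3 is methoxy in place of tert-butyl on an aromatic carbon. The measured steps show that removing a group at this carbon raises the number by a large margin and that the choice of alkyl group matters little. Methoxy is neither hydrogen nor an alkyl, so compound 4 is expected to fall between compound 1 and compound 3, nearer the weaker end: an estimated 40000 nM (range 12000 nM to 150000 nM), a step of a 4.5-fold higher number from compound 3 to compound 4 (0.65 log units; beyond the scatter).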

Compound 4, concentration for 50% growth inhibition: > 100000 nM
Compound 4 gave a limit, no number; the forecaster's own chance of this, stated with the estimate: 30%; at least 2.5-fold (0.39 log units) between middle value and limit.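

In this assay, methoxy at this aromatic carbon does not keep the growth inhibition seen with the two alkyl groups, with an at least 11-fold higher number from compound 3 to compound 4 (1.05 log units; beyond the scatter) and an at least 6.5-fold higher number from compound 2 to compound 4 (0.81 log units; beyond the scatter). The earlier compounds shown here showed only that butyl or tert-butyl gives a lower number than hydrogen; compound 4 adds that having a substituent here is not enough in itself, and that the identity of the group counts. Compound 1 and compound 4 both sit at a limit of the assay, so the step between them cannot be read: the limit of > 100000 nM in this assay, at which 2 of the 4 values shown sit.

On these data alone, whether methoxy differs at all from hydrogen at this carbon stays open. Also open, as far as these compounds go, is whether the lower numbers are confined to alkyl groups, which a shorter chain such as ethyl, a longer chain, an amine or a carboxylic acid at this carbon would help to settle.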